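A Shared Aryl Swap Tried on a Second Core

The source may report more compounds than this note shows. Statements on the series, on what has been measured and on what is new or still open speak of the compounds shown alone.

Measured compounds:
compound 1 `O=C(NCc1ccc(CNS(=O)(=O)c2ccccc2)cc1)c1cccc(F)c1` — 100 nM
compound 2 `Cc1ccccc1C(=O)NCc1ccc(CNS(=O)(=O)c2ccccc2)cc1` — 1 nM
compound 3 `Cc1ccc(S(=O)(=O)NCc2ccc(CNC(=O)c3cccc(F)c3)cc2)cc1` — 1 nM

All three were tested in an assay on MDA-MB-231 cells for binding affinity to C-X-C chemokine receptor type 4 (Homo sapiens), read by immunofluorescence and microscopy, with stated times of 10 min and 30 min; a lower number here means that less compound is needed, a higher number that more compound is needed for the effect. Compound 1 gives 100 nM in this assay. Compound 2 differs from compound 1 by 2-methylphenyl in place of 3-fluorophenyl on a carbonyl carbon, and this assay shows a 100-fold lower number from compound 1 to compound 2 (2.00 log units; beyond the scatter). Compound 3 differs from compound 1 in its core by methyl in place of hydrogen on an aromatic carbon, and this assay shows a 100-fold lower number from compound 1 to compound 3 (2.00 log units; beyond the scatter). Compound 3 and compound 2 are level at the digits given, together the lowest of the three numbers.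

Compound 4 `Cc1ccc(S(=O)(=O)NCc2ccc(CNC(=O)c3ccccc3C)cc2)cc1` has not yet been measured. It differs from compound 3 by 2-methylphenyl in place of 3-fluorophenyl on a carbonyl carbon, the same change, at the same place, that was seen once already and gave a 100-fold lower number from compound 1 to compound 2 (2.00 log units; beyond the scatter). Compound 4 is expected to show a 5.0-fold lower number from compound 3 to compound 4 (0.70 log units; beyond the scatter), a smaller step than the earlier one, resting on the earlier step and on compound 3 already giving 1 nM in this assay. Compound 4 is thus estimated at 0.2 nM, with a likely range from 0.02 nM to 2 nM.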

Compound 4, effective concentration (reported as EC, without a stated level of effect): 100 nM
The estimate for compound 4 lay 500-fold (2.70 log units) below the measured number, and the stated range ends below it.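

In this assay the swap of 3-fluorophenyl for 2-methylphenyl on a carbonyl carbon did not carry over from one core to the other, since it now gave a 100-fold higher number from compound 3 to compound 4 (2.00 log units; beyond the scatter) and so ran opposite to its earlier direction: the same change on two cores in this assay, a 100-fold lower number (2.00 log units; beyond the scatter) from compound 1 to compound 2 and a 100-fold higher number (2.00 log units; beyond the scatter) from compound 3 to compound 4, 10000-fold (4.00 log units) apart, beyond the scatter of two such steps.

Methyl in place of hydrogen on an aromatic carbon reversed in the same way, with a 100-fold higher number from compound 2 to compound 4 (2.00 log units; beyond the scatter) set against the lower number it gave on the core of compound 1: the same change on two cores in this assay, a 100-fold lower number (2.00 log units; beyond the scatter) from compound 1 to compound 3 and a 100-fold higher number (2.00 log units; beyond the scatter) from compound 2 to compound 4, 10000-fold (4.00 log units) apart, beyond the scatter of two such steps.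

Among these compounds, in these four compounds, then, neither the size nor the direction of either change held from one core to the other, though one pair per core shows only that the two changes depend on each other here, not why they do or whether this holds elsewhere.

The compounds shown leave open whether another group on the carbonyl carbon, such as cyclohexyl, would also change direction between the cores. They also leave open whether an ethyl or a methoxy group in place of the methyl on the aromatic carbon would follow the methyl.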